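Chloro to Fluoro on the Fused Ring of Compound 2

A few compounds are considered here, and "the series" means these few. Any claim that something is new, unique, unknown or untested is made for them only; others in the source may bear on it.

Compound 2 `O=S(=O)(c1ccc(F)cc1)c1cnc2ccc(Cl)cc2c1-c1ccc(Cl)cc1` carries a chloro group on the fused ring of its core. In an ADME assay on microsomes from liver (Homo sapiens) for metabolic stability, tested at 2.5 uM (a higher number here means faster removal of the compound, a lower number slower removal), compound 2 gives 0.01 mL/min, the lowest of the three measured numbers. Compound 1 `O=S(=O)(c1ccc(F)c(Cl)c1)c1cnc2c(F)cccc2c1-c1cccc(Cl)c1` gives 0.18 mL/min, and compound 3 `O=S(=O)(c1ccc(F)c(Cl)c1)c1cnc2c(F)cccc2c1-c1cccc(F)c1` gives 1.23 mL/min. The difference between the core of compound 2 and the core of compound 1 is not broken down here. Compound 1 and compound 3 differ by fluoro in place of chloro on an aromatic carbon, and that change made a 6.8-fold higher number from compound 1 to compound 3 (0.83 log units; beyond the scatter).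

Compound 4 `O=S(=O)(c1ccc(F)cc1)c1cnc2ccc(F)cc2c1-c1ccc(Cl)cc1` has not been measured; it differs from compound 2 by fluoro in place of chloro on an aromatic carbon. This is the same kind of change, not the same one: in compound 1 the swapped carbon sits on a ring of carbon only, meta to a large group, whereas in compound 2 it sits on a ring that is part of a fused or bridged system of two rings, meta to a fused ring and para to a fused ring. Resting on the single comparable step a 6.8-fold higher number from compound 1 to compound 3 (0.83 log units; beyond the scatter), the step expected for compound 4 in this assay is a 4.0-fold higher number from compound 2 to compound 4 (0.60 log units; beyond the scatter). Compound 4 is therefore estimated at 0.04 mL/min, expected to lie between 0.01 mL/min and 0.15 mL/min.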

Compound 4, intrinsic clearance in a liver preparation (reported as CLH), per the amount of preparation that the assay uses: 0.12 mL/min
The estimate for compound 4 lay 3.0-fold (0.48 log units) below the measured number; the range from low to high includes it.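

Putting fluoro in place of chloro made a 12-fold higher number from compound 2 to compound 4 (1.08 log units; beyond the scatter) in this assay, so the number rose on this core as it did on the core of compound 1. Set side by side, the two steps agree as closely as repeated measurements would: the same change on two cores in this assay, a 6.8-fold higher number (0.83 log units; beyond the scatter) from compound 1 to compound 3 and a 12-fold higher number (1.08 log units; beyond the scatter) from compound 2 to compound 4, 1.8-fold (0.24 log units) apart, within the scatter of two such steps

This shows that, for these two pairs, the change carried from one core to the other in both direction and size, even though the swapped carbon sits in a different kind of ring on each core. It does not show why the number rises, and two pairs cannot establish that the same step would appear on every core in the series.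

The compounds shown leave open whether a different group on that aromatic carbon, such as a nitrile, a methoxy group or an amine, would shift the number in the same way. They also leave open what fluoro in place of the chloro still present on compound 4 would do.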